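The source may report more compounds than this note shows. Statements on the series, on what has been measured and on what is new or still open speak of the compounds shown alone.

In a functional assay on HL-60 cells (Homo sapiens) for antiproliferative activity, read by XTT assay, with a stated time of 72 h (on this read-out higher numbers stand for weaker inhibition and lower numbers for stronger inhibition), compound 1 `COc1ncnc2c1c(-c1cccs1)cn2[C@@H]1O[C@H](CO)[C@@H](O)[C@H]1O` gives 80 nM. Compound 2 `CNc1ncnc2c1c(-c1cccs1)cn2[C@@H]1O[C@H](CO)[C@@H](O)[C@H]1O` is recorded in this assay only as a limit, > 20000 nM, and that is the limit of > 20000 nM in this assay, at which 1 of the 3 values shown sits. Compound 3 `CNc1ncnc2c1c(-c1ccco1)cn2[C@@H]1O[C@H](CO)[C@@H](O)[C@H]1O` gives 620 nM in this assay.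

Two single changes connect these three compounds. Going from compound 2 to compound 1 the change is methoxy in place of methylamino on an aromatic carbon, and it brings an at least 250-fold lower number from compound 2 to compound 1 (2.39 log units; beyond the scatter). The two cores differ by furan-2-yl in place of thiophen-2-yl on an aromatic carbon, and that change brings an at least 32-fold lower number from compound 2 to compound 3 (1.50 log units; beyond the scatter). Because one of the two starting values in each of these steps is the limit (the limit of > 20000 nM in this assay, at which 1 of the 3 values shown sits), both steps are known only as lower bounds on their size.

Compound 4 `COc1ncnc2c1c(-c1ccco1)cn2[C@@H]1O[C@H](CO)[C@@H](O)[C@H]1O` has not yet been measured in this assay. Going by the values given here, it differs from compound 3 by methoxy in place of methylamino on an aromatic carbon, which is the same change as the one from compound 2 to compound 1, made on the core that carries furan-2-yl instead of thiophen-2-yl. That earlier step was large, so a step of some size in the same direction is expected here as well, though its floor of an at least 250-fold lower number from compound 2 to compound 1 (2.39 log units; beyond the scatter) rests on a limit and cannot simply be carried over. Compound 1, the measured methoxy compound, gives 80 nM, and compound 4 is expected to land near that region. The step from compound 3 to compound 4 is therefore estimated at a 16-fold lower number from compound 3 to compound 4 (1.19 log units; beyond the scatter). For compound 4 the estimate in this assay is 40 nM, with an expected range from 5 nM to 250 nM.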

Compound 4, half-maximal inhibitory concentration: 100 nM
The estimate for compound 4 lay 2.5-fold (0.40 log units) below the measured number, within the range that was stated.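

In this assay, methoxy in place of methylamino on the core carrying furan-2-yl gives a 6.2-fold lower number from compound 3 to compound 4 (0.79 log units; beyond the scatter), so the change points the same way on both cores, but its size does not carry over from one to the other: the same change on two cores in this assay, an at least 250-fold lower number (2.39 log units; beyond the scatter) from compound 2 to compound 1 and a 6.2-fold lower number (0.79 log units; beyond the scatter) from compound 3 to compound 4, at least 40-fold (1.60 log units) apart, beyond the scatter of two such steps

Seen from the other side, furan-2-yl in place of thiophen-2-yl gives a 1.3-fold higher number from compound 1 to compound 4 (0.10 log units; within the scatter), so the two methoxy compounds are not told apart, although the same swap is large among the methylamino compounds: the same change on two cores in this assay, an at least 32-fold lower number (1.50 log units; beyond the scatter) from compound 2 to compound 3 and a 1.3-fold higher number (0.10 log units; within the scatter) from compound 1 to compound 4, at least 40-fold (1.60 log units) apart, beyond the scatter of two such steps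

These gaps show that the two changes do not act independently across these four compounds, but they do not show how large the methoxy step truly is on the core carrying thiophen-2-yl, and both gaps are only floors, as the value of compound 2 is a limit and not a number: the limit of > 20000 nM in this assay, at which 1 of the 4 values shown sits.

The compounds shown leave open whether a plain amine, a dimethylamino group or an ethoxy group on the same aromatic carbon would follow methoxy or methylamino. They also leave open whether the dependence on the core would persist with a phenyl ring in place of furan-2-yl or thiophen-2-yl.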